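Removing the phenyl group from compound 3

The source may hold more compounds than are shown below. What is called first, only, known or untested is meant among the compounds shown, and "the series" means these compounds.

The numbers below come from a functional assay on L1210 cells (Mus musculus) for inhibition, read by cell counting, with a stated time of 48 h (a lower number here means a stronger inhibitor, a higher number a weaker inhibitor), and cover three compounds.
Compound 1 `CCN(CC)CN1C(=O)/C(=N/NC(N)=S)c2cc(Cl)ccc21` gives 148000 nM
Compound 2 `CCN(CC)CN1C(=O)/C(=N/NC(=S)Nc2ccc(OC)cc2)c2ccccc21` gives 2400 nM
Compound 3 `CCN(CC)CN1C(=O)/C(=N/NC(=S)Nc2ccccc2)c2ccccc21` gives 13000 nM

Compound 3 has the second highest of the three numbers, with compound 2 nearest and compound 1 furthest. Compound 4 `CCN(CC)CN1C(=O)/C(=N/NC(N)=S)c2ccccc21` has yet to be measured. Its difference from compound 3 reads hydrogen in place of phenyl on an amide-type nitrogen and amounts to hydrogen in place of phenyl on an amide-type nitrogen, or anilino to amino.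

Going by the values given here, only one measured step touches this phenyl group, a 5.4-fold higher number from compound 2 to compound 3 (0.73 log units; beyond the scatter) and it is modest but beyond the scatter. Among the compounds with values here, no measured step removes the phenyl itself. Compound 1 also lacks a phenyl there, though its core differs too, and its number is the higher one, with compound 1 at 148000 nM and compound 3 at 13000 nM. A rise is therefore expected in this assay and the estimated step is a 6.2-fold higher number from compound 3 to compound 4 (0.79 log units; beyond the scatter) with some uncertainty. Compound 4 is expected at 80000 nM with an estimated range from 25000 nM to 250000 nM when tested.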

Compound 4, half-maximal inhibitory concentration: 121000 nM
Compound 4: the middle estimate sits 1.5-fold (0.18 log units) below what was measured, within the range that was stated.
By their numbers in this assay, from the lowest: compound 2; then compound 3; then compounds 4 and 1 (each within the scatter of the next).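

In this assay, taking the phenyl off the amide-type nitrogen gives a 9.3-fold higher number from compound 3 to compound 4 (0.97 log units; beyond the scatter) and so shows directly that the aromatic ring itself goes with the lower number at this position, beyond what its methoxy substituent adds. Replacing the whole 4-methoxyphenyl with hydrogen gives a 50-fold higher number from compound 2 to compound 4 (1.70 log units; beyond the scatter) as the widest step among these compounds, so the two changes at this position run in the same direction. The chloro group on the aromatic carbon gives only a 1.2-fold lower number from compound 1 to compound 4 (0.09 log units; within the scatter) and stays within the scatter in the compounds that lack the aryl group.

As far as these compounds go, whether a benzyl group or a short alkyl chain on that nitrogen would lie nearer compound 3 or compound 4 remains open, as does the effect of chloro where the phenyl is kept. Nothing shown gives a reason for these steps.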